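The compounds below may be only part of what the source reports. "The series", "measured", "known", "first", "only" and "open" are said of these compounds alone.

Measured compounds:
compound 1 `Cc1cc(S(=O)(=O)/N=C(\N)n2nccc2-c2ccccc2)c(SCc2ccc(Cl)cc2)cc1Cl`, which in a functional assay on HeLa cells (Homo sapiens) for cytotoxicity, read by MTT assay, with a stated time of 72 h (on this read-out lower numbers stand for stronger inhibition and higher numbers for weaker inhibition), gives 3000 nM
compound 2 `Cc1cc(-c2ccccc2)n(/C(N)=N/S(=O)(=O)c2cc(C)c(Cl)cc2SCc2cccc3ccccc23)n1`, which in this assay gives 3000 nM
compound 3 `Cc1cc(S(=O)(=O)/N=C(\N)n2nccc2-c2ccccc2)c(SCc2cccc3ccccc23)cc1Cl`, which in this assay gives 3000 nM

Compound 2 stands level with compounds 1 and 3 at the digits shown; its nearest neighbour is compound 1 and its furthest is compound 3, and both of those gaps lie within the scatter. Compound 4 `Cc1ccc(CSc2cc(Cl)c(C)cc2S(=O)(=O)/N=C(\N)n2nc(C)cc2-c2ccccc2)cc1` is not yet measured. It differs from compound 2 in one place: 4-methylphenyl in place of naphthalen-1-yl on a saturated chain carbon bound to a sulfur.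

Among the compounds with values here, two measured steps bear on this change. The most relevant is no change at the digits printed from compound 1 to compound 3 (within the scatter), a swap of the group on the saturated chain carbon bound to a sulfur, the very place touched in compound 4. The other is no change at the digits printed from compound 2 to compound 3 (within the scatter), a change elsewhere on the shared core that likewise left the read-out flat. On this basis the step from compound 2 to compound 4 is expected to be none beyond the scatter, no change at the digits printed from compound 2 to compound 4 (within the scatter). Compound 4 is therefore estimated at 3000 nM, within a range from 1500 nM to 6000 nM.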

Compound 4, half-maximal inhibitory concentration: 62000 nM
Beside the measured number, compound 4's estimate is 21-fold (1.32 log units) below it; the whole stated range lies below it.
By their numbers in this assay, from the lowest: compounds 1, 2 and 3 (each within the scatter of the next); then compound 4.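

In this assay, the group on the saturated chain carbon bound to a sulfur proves not to be freely interchangeable: 4-methylphenyl in place of naphthalen-1-yl gives a 21-fold higher number from compound 2 to compound 4 (1.32 log units; beyond the scatter). Within the data shown here, the only earlier swap at this place, no change at the digits printed from compound 1 to compound 3 (within the scatter), had left the read-out flat and so gave no sign that this position could respond at all. No measurement at hand accounts for the size of the new step.

The compounds shown leave open whether the step follows the loss of one of the two aromatic rings of naphthalen-1-yl or the methyl group of 4-methylphenyl, as the single swap changes both at once. They also leave open how a plain phenyl, or a phenyl carrying an amine or a carboxylic acid, would read out at this same place.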